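Trifluoromethyl in place of chloro: compound 3 to compound 4

This account rests on a few compounds, and the source may have more. Where it says the series, first, only, none or still open, it means among the compounds named here.

Values in an ADME assay on L6 cells (Rattus norvegicus) for cytotoxicity, read by resazurin assay, with a stated time of 72 h (on this read-out lower numbers stand for stronger inhibition and higher numbers for weaker inhibition), so far:
compound 1 `OC(c1ccc(Cl)cc1)(c1ccc(C(F)(F)F)cc1)c1cccnc1` gives 56400 nM
compound 2 `OC(c1ccc(Br)cc1)(c1ccc(C(F)(F)F)cc1)c1cccnc1` gives 54700 nM
compound 3 `NC(=O)c1cccc(C(O)(c2ccc(Cl)cc2)c2cccnc2)c1` gives > 100000 nM as a limit of the assay

Compound 3 has no exact number, only the limit > 100000 nM in this assay as its standing. Compound 4 `NC(=O)c1cccc(C(O)(c2ccc(C(F)(F)F)cc2)c2cccnc2)c1` differs from it by trifluoromethyl in place of chloro on an aromatic carbon with trifluoromethyl in place of chloro on an aromatic carbon, para to a large group. Among the measured compounds shown here, the only measured step is a 1.0-fold lower number from compound 1 to compound 2 (0.01 log units; within the scatter) for bromo in place of chloro, and it lies within the scatter. It is a different exchange, so it gives only weak guidance. No step beyond the scatter is expected in this assay, and a second limit is quite possible. The expected step is a number no higher from compound 3 to compound 4 (the limit leaves the size open) on this estimate. Compound 4 is estimated at 100000 nM within an expected range from 50000 nM to 200000 nM in this read-out.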

Compound 4, half-maximal inhibitory concentration: > 100000 nM
Compound 4: a limit, no number; the forecaster's own chance of this, stated with the estimate: 55%; the middle value sits exactly at the limit.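

In this assay, compound 4 is a limit, as compound 3 is, so a limit now stands with either trifluoromethyl or chloro at this position, and the step between them cannot be read. Exchanging the halophenyl for 3-carbamoylphenyl gives an at least 1.8-fold higher number from compound 2 to compound 4 (0.26 log units; that floor lies within the scatter) and an at least 1.7-fold higher number from compound 1 to compound 4 (0.24 log units; that floor lies within the scatter); both floors lie within the scatter, so no true rise can be claimed. The read-out leaves little room at this end: the limit of > 100000 nM in this assay, at which 2 of the 4 values shown sit.

From the compounds shown here alone, whether an amine or a carboxylic acid at this position would bring a number below the limit remains open. So does the size of any step from 3-carbamoylphenyl.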